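The compounds below may be only part of what the source reports. "The series", "measured", "known", "first", "only" and "open" are said of these compounds alone.

Among the measured compounds shown here, compound 1 `CCCSc1nc(N)c2nc(O)n(Cc3ccccc3)c2n1` stands at the head of the set: in a functional assay (spleen, spleen) for activation, with Mus musculus as the target (on this read-out higher numbers stand for an effect only at larger amounts of compound and lower numbers for an effect already at smaller amounts), compound 1 gives 0.01 uM, the only number among the values shown. Compound 2 `Nc1ncnc2c1nc(O)n2C1CCCC1` returns only a limit in this assay, > 10 uM. For the measured compounds named here, no step between measured compounds that differ in one place is available here. Compound 3 `CCCC[S+]([O-])c1nc(N)c2nc(O)n(Cc3ccccc3)c2n1` is obtained from compound 1 by the change (a group of 6 heavy atoms (4 carbon, 1 oxygen, 1 sulfur; no ring) in place of a group of 4 heavy atoms (3 carbon, 1 sulfur; no ring), on an aromatic carbon). In this assay the step of a 5.0-fold higher number from compound 1 to compound 3 (0.70 log units; beyond the scatter) is expected to be a modest loss, somewhat beyond the scatter. Compound 3 is therefore estimated at 0.05 uM, within a range from 0.01 uM to 0.3 uM.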

Compound 3, minimum effective concentration: 0.01 uM
For compound 3 the middle estimate is 5.0-fold (0.70 log units) above the measured one, within the range that was stated.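

In this assay, putting the group of 6 heavy atoms in place of propylsulfanyl, on the aromatic carbon between two ring nitrogen atoms, gives no change at the digits printed from compound 1 to compound 3 (within the scatter). Among the compounds shown here, this is the first reading at this position, and it shows that the position accepts a larger group carrying oxygen as well as sulfur without a measurable shift in the read-out. Nothing shown here accounts for this tolerance. From the compounds shown here alone, whether an amine, a carboxylic acid or a longer chain at this position would keep the same level remains open.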